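Bromine on the amide aryl ring: notes on compounds 1 to 4

This account rests on a few compounds, and the source may have more. Where it says the series, first, only, none or still open, it means among the compounds named here.

Measured so far:
compound 1, `Cc1ccc(NC(=O)c2cccc(OCCCCn3ccnc3)c2)cc1Nc1nccc(-c2cccnc2)n1`; in a functional assay on K562 cells (Homo sapiens) for cytotoxicity, read by XTT assay, with a stated time of 24 h (on this read-out higher numbers stand for weaker inhibition and lower numbers for stronger inhibition), compound 1 gives 74600 nM
compound 3, `Cc1ccc(NC(=O)c2ccc(OCCCCn3ccnc3)cc2)cc1Nc1nccc(-c2cccnc2)n1`; compound 3 gives 49900 nM
compound 2, `Cc1ccc(NC(=O)c2ccc(OCCCCn3ccnc3)c(Br)c2)cc1Nc1nccc(-c2cccnc2)n1`; compound 2 gives 12000 nM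

Compounds 1 and 3 are built from the same atoms joined differently; the difference between the two cores is not broken down here. Their values in this assay lie within the scatter of each other. Compound 2 arises from compound 3 by bromo in place of hydrogen on an aromatic carbon, and that step gives a 4.2-fold lower number from compound 3 to compound 2 (0.62 log units; beyond the scatter).

Compound 4, `Cc1ccc(NC(=O)c2cc(Br)cc(OCCCCn3ccnc3)c2)cc1Nc1nccc(-c2cccnc2)n1`, is not yet measured. It arises from compound 1 by bromo in place of hydrogen on an aromatic carbon. This is the same kind of change as that from compound 3 to compound 2, but not the same: in compound 2 the bromo is ortho to the 4-(1H-imidazol-1-yl)butoxy group, in compound 4 it is meta to that group; in both it is meta to a large group.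

For compound 4 the expected step is a 2.5-fold lower number from compound 1 to compound 4 (0.40 log units; beyond the scatter), set below the earlier one because a 4.2-fold lower number from compound 3 to compound 2 (0.62 log units; beyond the scatter) is a single example at a different place. Compound 4 is estimated at 30000 nM, between 10000 nM and 80000 nM.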

Compound 4, half-maximal inhibitory concentration: 6500 nM
The estimate for compound 4 lay 4.6-fold (0.66 log units) above the measured number; the whole stated range lies above it.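

In this assay bromo in place of hydrogen lowers the number on both cores, and the new step is an 11-fold lower number from compound 1 to compound 4 (1.06 log units; beyond the scatter). The direction of the change carries from one core to the other, but its size does not: the same change on two cores in this assay, a 4.2-fold lower number (0.62 log units; beyond the scatter) from compound 3 to compound 2 and an 11-fold lower number (1.06 log units; beyond the scatter) from compound 1 to compound 4, 2.8-fold (0.44 log units) apart, beyond the scatter of two such steps The two steps differ both in the core and in where the bromo sits relative to the 4-(1H-imidazol-1-yl)butoxy group, so the gap cannot be assigned to either one, and two examples set no rule for any other core.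

The compounds shown leave open whether the step belongs to bromo itself or would also appear with a chloro or a methyl group on the same carbon of the core of compound 1. They also leave open whether it survives when the 4-(1H-imidazol-1-yl)butoxy group gives way to a longer chain or to a chain ending in an amine.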